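The source may hold more compounds than are shown below. What is called first, only, known or untested is meant among the compounds shown, and "the series" means these compounds.

Measured in a functional assay on HUVEC cells (Homo sapiens) for cytotoxicity; a higher number here means that more compound is needed for the effect, a lower number that less compound is needed:
compound 1 (`COC1=C(C)C(=O)/C(=C(O)/C=C/c2ccccc2C)C(=O)C1(C)C`) : 2.3 ug/mL
compound 2 (`CCc1ccc(/C=C/C(O)=C2/C(=O)C(C)=C(OC)C(C)(C)C2=O)cc1`) : "not determined" (no result reported)
compound 3 (`COC1=C(C)C(=O)/C(=C(O)/C=C/c2ccco2)C(=O)C1(C)C`) : 2.4 ug/mL

Compound 3 gives 2.4 ug/mL and shares its place with compound 1, since the two numbers lie within the scatter of each other. Compound 2 offers no number for comparison.

The next compound, compound 4 (`COC1=C(C)C(=O)/C(=C(O)/C=C/c2cccs2)C(=O)C1(C)C`), has thiophen-2-yl in place of furan-2-yl on a double-bonded chain carbon bound to a double-bonded chain carbon. Among the measured compounds shown here, no measured step covers this exchange directly. The closest evidence is the change at the same place, a 1.0-fold higher number from compound 1 to compound 3 (0.02 log units; within the scatter), which stayed within the scatter even though a 2-methylphenyl group gave way to furan-2-yl. On this single step, no change beyond the scatter is expected in this assay for the exchange of one five-membered aromatic ring for another. The expected step is no change at the digits printed from compound 3 to compound 4 (within the scatter). The estimated value for compound 4 is 2.4 ug/mL, with an expected range from 1.1 ug/mL to 5 ug/mL.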

Compound 4, concentration for half-maximal effect: 2.5 ug/mL
The estimate for compound 4 lay 1.0-fold (0.02 log units) below the measured number; the measured number falls inside the stated range.
By their numbers in this assay, from the lowest: compounds 1, 3 and 4 (each within the scatter of the next).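

In this assay, among the compounds shown here, thiophen-2-yl in place of furan-2-yl on a double-bonded chain carbon bound to a double-bonded chain carbon gives a 1.0-fold higher number from compound 3 to compound 4 (0.02 log units; within the scatter) and is the first direct reading of one five-membered aromatic ring against another at this place. Thiophen-2-yl in place of 2-methylphenyl gives a 1.1-fold higher number from compound 1 to compound 4 (0.04 log units; within the scatter), so the three groups with a number here, two five-membered aromatic rings with a hetero atom and one substituted phenyl, all lie within the scatter of one another. Nothing in the data shown bears on the reason for this sameness.

On these data alone, whether the number would stay within the scatter with an amine or a carboxylic acid at this place remains open. The compounds shown also cannot tell how a longer chain, or a change to the shared core, would read in this assay.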